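The compounds below may be only part of what the source reports. "The series", "measured", "known", "first", "only" and "open" are said of these compounds alone.

Working notes on the series. Three compounds have numbers in a functional assay on cells for positive allosteric modulation of metabotropic glutamate receptor 2 (Homo sapiens), read by fluorescence and calcium flux, with a stated time of 30 min; on this read-out lower numbers stand for an effect already at smaller amounts and higher numbers for an effect only at larger amounts of compound. Compound 1 `Fc1cc(Cl)ccc1-c1ccc(Cn2nnc3ccccc32)cn1` gives 50 nM in this assay. Compound 2 `Brc1cccc2c1nnn2CC1CCCC1` gives 30 nM in this assay. Compound 3 `Clc1cccc2c1nnn2CC1CC1` gives 90 nM in this assay, the highest of the three numbers; the number of compound 1 lies within the usual scatter of it, while the number of compound 2 lies lower by more than the scatter. Within the data shown here, compound 3 and compound 2 differ in more than one place, so no single step between them can be read off.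

Compound 4 `COc1cccc2c1nnn2CC1CC1` is not yet measured in this assay. It differs from compound 3 in one place: methoxy in place of chloro on an aromatic carbon. Among the measured compounds shown here, no measured pair shows this kind of exchange, so the direction of the step rests on the general range of the series alone. The expectation is a small step for the worse or none beyond the scatter, a 1.7-fold higher number from compound 3 to compound 4 (0.22 log units; within the scatter). Compound 4 is estimated at 150 nM in this assay, with a plausible range from 50 nM to 500 nM.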

Compound 4, half-maximal effective concentration: 400 nM
Compound 4: middle estimate off by 2.7-fold (0.43 log units), on the low side, and the stated range covers the measured number.
By their numbers in this assay, from the lowest: compounds 2, 1 and 3 (each within the scatter of the next, the first and the last beyond it); then compound 4.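

In this assay, among these compounds, the exchange of chloro for methoxy on an aromatic carbon, ortho to a fused ring, gives a 4.4-fold higher number from compound 3 to compound 4 (0.65 log units; beyond the scatter) and is the first single-place step. The step lies beyond the scatter, so this position does not treat the two groups alike, at least with the side chain of compound 3. No measurement of any property of the two groups bears on this step, and the data offer no explanation for it.

Open, on these data alone, is how an amine, a methyl or a carboxylic acid on this same carbon would read against chloro and methoxy. Also open, as far as these compounds go, is whether the exchange gives a step of similar size on another side chain, such as that of compound 2, which carries bromo at this place and differs from compound 3 in more than one place, so that no step can be read between them.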